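A few compounds are considered here, and "the series" means these few. Any claim that something is new, unique, unknown or untested is made for them only; others in the source may bear on it.

Compound 1 `Cc1cc(C)n(-c2ccc(S(=O)(=O)NC(=O)NNC(=N)N)cc2)n1`: 3%
Compound 2 `CCCCNC(=O)NS(=O)(=O)c1ccc(-n2nc(C)cc2C)cc1`: 2%

The two measured compounds share one core and differ only in the group carried on the sulfonamide nitrogen. In a functional assay on the whole organism (blood, strain albino) with Mus musculus as the target, with stated times of 6 days and 4 h, at a dose of 0.4 mmol/kg by the oral route (on this read-out lower numbers stand for less inhibition and higher numbers for more inhibition at the one dose given (going by the name of the read-out)), compound 2 gives 2%, the lowest of the two numbers, and compound 1 gives 3%; the step of a number 1 percentage points lower from compound 1 to compound 2 (within the scatter) lies within the scatter, so neither compound can be placed above the other on this read-out.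

Compound 3 `CCNC(=S)NS(=O)(=O)c1ccc(-n2nc(C)cc2C)cc1` has not yet been measured. It differs from compound 2 in one place: a group of 5 heavy atoms (3 carbon, 1 nitrogen, 1 sulfur; no ring) in place of a group of 7 heavy atoms (5 carbon, 1 nitrogen, 1 oxygen; no ring), on a sulfonamide nitrogen

Among the compounds with values here, the only measured step, a number 1 percentage points lower from compound 1 to compound 2 (within the scatter), also exchanged the group on the sulfonamide nitrogen and left the read-out within the scatter. Within the data shown here, no measured pair tests a change of the kind that turns compound 2 into compound 3, so the expectation rests on that single step and on the low level of both measured compounds. The step of a number 1 percentage points higher from compound 2 to compound 3 (within the scatter) is therefore expected to stay within the scatter. Compound 3 is estimated to give 3% in this assay, with a range from -4% to 12%.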

Compound 3, a percentage reported as inhibition, in the whole organism at one dose (the size of the read-out at that dose, not a potency): 0%
For compound 3 the middle estimate is 3 percentage points above the measured one; low and high end bracket the measured number.
By their numbers in this assay, from the lowest: compounds 3, 2 and 1 (each within the scatter of the next).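

Exchanging butylcarbamoyl on the sulfonamide nitrogen for the smaller, sulfur-bearing group gives a number 2 percentage points lower from compound 2 to compound 3 (within the scatter) in this assay. Set against the group of compound 1, the same sulfur-bearing group gives a number 3 percentage points lower from compound 1 to compound 3 (within the scatter). Where the earlier compounds offered a single exchange at this position, there are now three groups on the sulfonamide nitrogen, differing in size and in holding oxygen or sulfur, and at the one dose given the read-out does not separate any of them.

As far as these compounds go, this exchange alters both the size of the group and the atom on the double bond, so the two changes cannot be told apart here, and it remains open how an ethylcarbamoyl group or a butyl chain on the sulfur-bearing group would read, or whether a group carrying a carboxylic acid or a cyclohexyl ring on this nitrogen would lift the read-out clear of the scatter. Nothing on hand offers an explanation for how these three compounds read.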